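The source may report more compounds than this note shows. Statements on the series, on what has been measured and on what is new or still open speak of the compounds shown alone.

Compounds measured so far:
compound 1 `Cc1cn([C@@H]2O[C@H](CO[Si](C)(C)C(C)(C)C)[C@@]3(OS(=O)(=O)C=C3NC(=O)c3ccccc3)[C@H]2O[Si](C)(C)C(C)(C)C)c(=O)n(C)c1=O` — 4910 nM
compound 2 `COC(=O)CC(=O)NC1=CS(=O)(=O)O[C@@]12[C@@H](CO[Si](C)(C)C(C)(C)C)O[C@@H](n1cc(C)c(=O)n(C)c1=O)[C@@H]2O[Si](C)(C)C(C)(C)C` — 29700 nM

In a functional assay on CCRF-CEM cells (Homo sapiens) (on this read-out higher numbers stand for lower toxicity in this test and lower numbers for higher toxicity in this test), compound 1 gives the lowest of the two numbers; the nearest is compound 2, which stands a 6.0-fold higher number from compound 1 to compound 2 (0.78 log units; beyond the scatter) away. That single step, a 6.0-fold higher number from compound 1 to compound 2 (0.78 log units; beyond the scatter), is the only one recorded in this assay, and it replaced the phenyl on the carbonyl carbon with a (methoxycarbonyl)methyl.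

Compound 3 `Cc1cn([C@@H]2O[C@H](CO[Si](C)(C)C(C)(C)C)[C@@]3(OS(=O)(=O)C=C3NCCC(=O)O)[C@H]2O[Si](C)(C)C(C)(C)C)c(=O)n(C)c1=O` has not yet been measured in this assay. Its change from compound 1 is 2-carboxyethyl in place of benzoyl on an amine nitrogen. The measured step bears on it only loosely: in compound 2 the benzoyl was kept as an amide and only the phenyl was swapped, whereas in compound 3 the benzoyl is removed altogether and a 2-carboxyethyl sits on the amine nitrogen. Both changes, however, move from an aromatic ring to an open chain with an added oxygen, so a higher number in this assay is expected, of a size comparable to that seen from compound 1 to compound 2. For compound 3 the number is therefore estimated at 30000 nM, within 8000 nM to 120000 nM, a step of a 6.1-fold higher number from compound 1 to compound 3 (0.79 log units; beyond the scatter) from compound 1 that is expected to lie beyond the scatter.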

Compound 3, half-maximal cytotoxic concentration: 19400 nM
The estimate for compound 3 lay 1.5-fold (0.19 log units) above the measured number; the range from low to high includes it.
By their numbers in this assay, from the lowest: compound 1; then compounds 3 and 2 (each within the scatter of the next).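

In this assay, the benzamido group of compound 1 can be exchanged whole, not only at its phenyl: with 2-carboxyethyl in place of benzoyl on the amine nitrogen, the result is a 4.0-fold higher number from compound 1 to compound 3 (0.60 log units; beyond the scatter). The two open-chain groups cannot be told apart, since a 1.5-fold lower number from compound 2 to compound 3 (0.18 log units; within the scatter), although the ((methoxycarbonyl)methyl)carbonyl group keeps a carbonyl directly on the nitrogen and the 2-carboxyethyl group does not. Among these three compounds, then, only compound 1 carries the six-membered aromatic ring and stands apart from the other two, but no independent data explain this difference.

As far as these compounds go, it remains open whether the separation from compound 1 follows the loss of the phenyl ring or the presence of oxygen in the open chains, and a cyclohexanecarbonyl group or a plain alkyl chain on the same nitrogen would help to separate the two. Also unsettled is what the carboxylic acid of compound 3 contributes, a question that its methyl ester, a longer chain ending in the acid, or a chain ending in an amine could address.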